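Replacing the aryl piperazine cap with a carbamate

The source may report more compounds than this note shows. Statements on the series, on what has been measured and on what is new or still open speak of the compounds shown alone.

Compound 3 `COc1ccc(S(=O)(=O)NCCCN2CCN(c3ccc(C(C)=O)cc3)CC2)cc1` sits at the floor of what was measured: in an assay on CHO cells for displacement of a labelled ligand from 5-hydroxytryptamine receptor 7 (Homo sapiens) (on this read-out higher numbers stand for weaker inhibition and lower numbers for stronger inhibition), compound 3 gives only the limit > 10000 nM. Compound 1 `COc1ccc(S(=O)(=O)NCCCN2CCN(c3cccc(C(F)(F)F)c3)CC2)cc1` gives 89 nM in this assay. Compound 2 `COc1ccc(S(=O)(=O)NCCCN2CCN(c3ccccc3)CC2)cc1` gives only the limit > 10000 nM in this assay. The step of an at least 110-fold higher number from compound 1 to compound 2 (2.05 log units; beyond the scatter) and the step of an at least 110-fold higher number from compound 1 to compound 3 (2.05 log units; beyond the scatter) are both large losses; the step that the two limits leave unreadable from compound 2 to compound 3 cannot be read, as the limit of > 10000 nM in this assay, at which 2 of the 3 values shown sit, shows. Compound 4 `COc1ccc(S(=O)(=O)NCCCN2CCN(C(=O)OCc3ccccc3)CC2)cc1` differs from compound 3 by benzyloxycarbonyl in place of 4-acetylphenyl on an amine nitrogen in a ring. The two measured steps that bear on this change both show that altering the group on the ring nitrogen away from 3-(trifluoromethyl)phenyl moves the number to the limit, and the new group is again not that one. The author therefore expects no step beyond the scatter, the estimated step being a step that the limit leaves unreadable from compound 3 to compound 4. Compound 4 is estimated at 15000 nM, with a range from 3000 nM to 60000 nM, most likely reported as a limit.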

Compound 4, half-maximal inhibitory concentration: > 10000 nM
Compound 4 was reported as a limit; the forecaster's own chance of this, stated with the estimate: 70%; the middle value does not contradict the limit.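

In this assay, the loss on leaving 3-(trifluoromethyl)phenyl is no longer confined to the phenyl and 4-acetylphenyl groups: benzyloxycarbonyl, which brings a carbonyl and a further oxygen to the amine nitrogen in the ring, gives an at least 110-fold higher number from compound 1 to compound 4 (2.05 log units; beyond the scatter). Of the four groups now shown on that nitrogen, only 3-(trifluoromethyl)phenyl gives a value that is not a limit: the limit of > 10000 nM in this assay, at which 3 of the 4 values shown sit. The steps to compound 4 from compound 2 and from compound 3 cannot be read, since each joins two limits.

From the compounds shown here alone, the order of compound 2, compound 3 and compound 4 remains open. Going by these compounds, it is also open whether a 3-chlorophenyl or 3-methoxyphenyl group on that nitrogen would give a value clear of the limit, or whether trifluoromethyl on the benzyloxycarbonyl ring would.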